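This account rests on a few compounds, and the source may have more. Where it says the series, first, only, none or still open, it means among the compounds named here.

Of the compounds shown here, two sharing the same core have been measured in an assay on CCRF-CEM cells for displacement of a labelled ligand from C-X-C chemokine receptor type 4 (Homo sapiens); on this read-out lower numbers stand for stronger inhibition and higher numbers for weaker inhibition. Compound 1 `CN(/C(=N/C1CCCCC1)SCC1=CSC2=NCCN12)C1CCCCC1` gives 3580 nM. Among the compounds with values here, compound 2 `C1=C(CS/C(=N\C2CCCCC2)NC2CCCCCCC2)N2CCN=C2S1` gives 28 nM, the lowest of the two numbers, and the only step between them, a 130-fold lower number from compound 1 to compound 2 (2.11 log units; beyond the scatter), shows that the group carried on the amine nitrogen weighs heavily on this read-out. Compound 3 `C1=C(CS/C(=N\C2CCCCC2)Nc2ccccc2)N2CCN=C2S1` has not yet been tested. It differs from compound 2 in one place: phenyl in place of cyclooctyl on an amine nitrogen, so that a cyclooctylamino becomes an anilino. Within the data shown here, the single measured step bears on this change only loosely, since it exchanged one saturated ring for another on the same nitrogen, whereas here a saturated ring gives way to an aromatic one. It does show that changes at this nitrogen can move the number a long way, so a step beyond the scatter is expected, more likely towards a higher number because compound 2 already gives 28 nM as the lowest number measured. The estimate for compound 3 in this assay is 300 nM, with a range from 40 nM to 3000 nM, which amounts to an expected step of an 11-fold higher number from compound 2 to compound 3 (1.03 log units; beyond the scatter).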

Compound 3, half-maximal inhibitory concentration: > 10000 nM
Compound 3 ended at the assay's limit; the forecaster's own chance of this, stated with the estimate: 5%; at least 33-fold (1.52 log units) between middle value and limit.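

In this assay compound 3 gives > 10000 nM, which is a limit of the assay and not a number: the limit of > 10000 nM in this assay, at which 1 of the 3 values shown sits.

Setting phenyl in place of cyclooctyl on this amine nitrogen gives an at least 350-fold higher number from compound 2 to compound 3 (2.55 log units; beyond the scatter), so the earlier finding that this nitrogen's group matters now extends to a swap from a saturated ring to an aromatic one, and here the direction is clear while the full size of the step is not. The anilino group also compares poorly with the cyclohexyl(methyl)amino group of compound 1, itself far weaker than compound 2, with an at least 2.7-fold higher number from compound 1 to compound 3 (0.44 log units; beyond the scatter), so this change takes the number beyond anything the two saturated-ring compounds gave.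

The compounds shown leave open whether the loss goes with the aromatic ring or with the smaller ring, since phenyl is six-membered and aromatic while cyclooctyl is eight-membered and non-aromatic, and the two differences arrive together. A cycloheptyl ring or a benzyl group on the same nitrogen would be needed to pull these apart, and nothing here says how either would read.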